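Triazole aryl variation on a triterpenoid ester: antiproliferative series

The compounds below may be only part of what the source reports. "The series", "measured", "known", "first", "only" and "open" are said of these compounds alone.

Measured compounds:
compound 1 `C/C(=C\CC/C(C)=C/CC[C@@H]1[C@@]2(C)CCC(=O)C(C)(C)[C@H]2CC[C@@]1(C)O)CC/C=C(\C)C(=O)OCc1cn(-c2ccccc2C(F)(F)F)nn1` — > 150000 nM
compound 2 `C/C(=C\CC/C(C)=C/CC[C@@H]1[C@@]2(C)CCC(=O)C(C)(C)[C@H]2CC[C@@]1(C)O)CC/C=C(\C)C(=O)OCc1cn(-c2ccccc2)nn1` — > 150000 nM
compound 3 `C/C(=C\CC/C(C)=C/CC[C@@H]1[C@@]2(C)CCC(=O)C(C)(C)[C@H]2CC[C@@]1(C)O)CC/C=C(\C)C(=O)OCc1cn(-c2ccc(Cl)cc2)nn1` — > 150000 nM

In a functional assay on A549 cells (Homo sapiens) for antiproliferative activity, read by MTT assay, with a stated time of 48 h (on this read-out higher numbers stand for weaker inhibition and lower numbers for stronger inhibition), compound 1 returns only a limit, > 150000 nM, not a number. Compound 2 likewise returns a limit in this assay, > 150000 nM. Compound 3 also returns a limit, > 150000 nM. Accordingly the steps a step that the two limits leave unreadable from compound 1 to compound 2 and a step that the two limits leave unreadable from compound 1 to compound 3 cannot be read; the limit of > 150000 nM in this assay, at which 3 of the 3 values shown sit, is the whole of the evidence, and it gives no direction. Compound 1 therefore stands at the same limit as both other measured compounds, with no ranking among the three possible.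

The unmeasured compound 4 `C/C(=C\CC/C(C)=C/CC[C@@H]1[C@@]2(C)CCC(=O)C(C)(C)[C@H]2CC[C@@]1(C)O)CC/C=C(\C)C(=O)OCc1cn(-c2ccc(C(C)(C)C)cc2)nn1` differs from compound 1 by 4-(tert-butyl)phenyl in place of 2-(trifluoromethyl)phenyl on an aromatic nitrogen. The two measured steps that bear on this change, from compound 1 to compound 2 and from compound 1 to compound 3, are both unreadable, so no size or direction can be derived for the expected step; the expectation is that compound 4 again sits at the limit, and the expected step is a step that the limit leaves unreadable from compound 1 to compound 4. The estimated value for compound 4 in this assay is 200000 nM, with an expected range from 60000 nM to 600000 nM.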

Compound 4, half-maximal inhibitory concentration: > 150000 nM
Compound 4: only a limit was reported; the forecaster's own chance of this, stated with the estimate: 80%; the middle value does not contradict the limit.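

In this assay compound 4 gives only a limit, > 150000 nM, so its steps from compound 1, compound 2 and compound 3 cannot be read: the limit of > 150000 nM in this assay, at which 4 of the 4 values shown sit.

The compounds shown leave open whether these four aryl groups differ at all in antiproliferative activity.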